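Positional fluoro change on the anilino ring of compound 3

This account rests on a few compounds, and the source may have more. Where it says the series, first, only, none or still open, it means among the compounds named here.

Measured so far in a functional assay on U2OS cells (Homo sapiens) for cytotoxicity, read by MTT assay, with a stated time of 48 h; a higher number here means a weaker inhibitor, a lower number a stronger inhibitor:
compound 1 `Fc1cccc(-c2nc(Nc3ccccc3)c3cc(F)ccc3n2)c1` gives 47600 nM
compound 2 `COc1ccc(Nc2nc(-c3cccc(F)c3)nc3ccc(F)cc23)cc1` gives 32300 nM
compound 3 `Fc1cccc(Nc2nc(-c3cccc(F)c3)nc3ccc(F)cc23)c1` gives 49600 nM

Compound 3 holds the highest of the three numbers, yet its nearest neighbour is compound 1 with a 1.0-fold higher number from compound 1 to compound 3 (0.02 log units; within the scatter), and its furthest is compound 2 with a 1.5-fold higher number from compound 2 to compound 3 (0.19 log units; within the scatter); every pair of values lies within the scatter, so no order among the three can be claimed.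

Compound 4 `Fc1cccc(-c2nc(Nc3ccccc3F)c3cc(F)ccc3n2)c1` differs from compound 3 by 2-fluorophenyl in place of 3-fluorophenyl on a nitrogen on an aromatic ring. The steps that touch the same position, a 1.0-fold higher number from compound 1 to compound 3 (0.02 log units; within the scatter) and a 1.5-fold lower number from compound 1 to compound 2 (0.17 log units; within the scatter), show that changes on this ring have not moved this assay beyond the scatter. Within the data shown here, no step in the set beyond the scatter bears on the new compound.

Compound 4 is therefore expected near 45000 nM, within 22000 nM to 90000 nM. The expected step is a 1.1-fold lower number from compound 3 to compound 4 (0.04 log units; within the scatter), not beyond the scatter.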

Compound 4, half-maximal inhibitory concentration: > 50000 nM
Compound 4: no number, only a limit (the forecaster's own chance of this, stated with the estimate: 10%); middle value at least 1.1-fold (0.04 log units) from the limit.
By their numbers in this assay, from the lowest: compounds 2, 1 and 3 (each within the scatter of the next). At a limit, above all of these: compound 4.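

In this assay compound 4, with 2-fluorophenyl in place of 3-fluorophenyl on the nitrogen, gives only a limit of the assay, > 50000 nM, not a number. The step, a number no lower from compound 3 to compound 4 (the limit leaves the size open), cannot be read in size, while the floors of an at least 1.5-fold higher number from compound 2 to compound 4 (0.18 log units; that floor lies within the scatter) and an at least 1.0-fold higher number from compound 1 to compound 4 (0.02 log units; that floor lies within the scatter) stay within the scatter. This fluoro change therefore gives no lower number, and its true size stays hidden.

From the compounds shown here alone, whether any change on this ring can move this assay beyond the scatter remains open. A carboxylic acid or an amine there would test this.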